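The source may hold more compounds than are shown below. What is called first, only, known or untested is meant among the compounds shown, and "the series" means these compounds.

Working notes on the series.

Three compounds have numbers in a functional assay on the whole organism with Rattus norvegicus as the target (on this read-out lower numbers stand for an effect already at smaller amounts and higher numbers for an effect only at larger amounts of compound), so far. Compound 1 `C=CCc1c(SC)nc2nc(C(=O)c3ccccc3)cn2c1C` gives 5 mg/kg in this assay. Compound 2 `CCc1c(SC)nc2nc(C(=O)c3ccccc3)cn2c1C` gives 2 mg/kg. Compound 3 `CCCc1cc(SC)nc2nc(C(=O)c3ccccc3)cn12` gives 10 mg/kg, the highest of the three numbers: against compound 1 the gap lies within the scatter, against compound 2 it is beyond it. Within the data shown here, the one step measured within the set, a 2.5-fold lower number from compound 1 to compound 2 (0.40 log units; beyond the scatter), shows that shortening a chain on a saturated chain carbon bound to an aromatic carbon lowered the number by a modest but real margin.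

Compound 4 `CSc1cc(C)n2cc(C(=O)c3ccccc3)nc2n1` is not yet measured. It differs from compound 3 by hydrogen in place of ethyl on a saturated chain carbon bound to an aromatic carbon. Among the measured compounds shown here, this is again a shortening of a chain at the same kind of place, so the step from compound 1 to compound 2 is the only measured step that bears on it, and it was modest. Compound 3 and compound 4 do not, however, carry the methyl group that compound 1 and compound 2 share, so how far the pattern transfers is open. A step of about the same size or none beyond the scatter is expected, in the direction of a lower number: a 1.7-fold lower number from compound 3 to compound 4 (0.22 log units; within the scatter) is the estimated step. Compound 4 is therefore expected to give 6 mg/kg in this assay, with a range from 2 mg/kg to 15 mg/kg.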

Compound 4, minimum effective dose: 5 mg/kg
Compound 4: the middle estimate sits 1.2-fold (0.08 log units) above what was measured; low and high end bracket the measured number.
By their numbers in this assay, from the lowest: compound 2; then compounds 1, 4 and 3 (each within the scatter of the next).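

Cutting propyl to methyl on a saturated chain carbon bound to an aromatic carbon gives a 2.0-fold lower number from compound 3 to compound 4 (0.30 log units; within the scatter) in this assay, so the length of this chain has no effect here that can be told from the scatter. On an aromatic carbon the outcome depends on the group that leaves: hydrogen in place of ethyl gives a 2.5-fold higher number from compound 2 to compound 4 (0.40 log units; beyond the scatter), while hydrogen in place of allyl gives no change at the digits printed from compound 1 to compound 4 (within the scatter), so of these two groups only ethyl stands apart from hydrogen at this place. Nothing at hand gives a reason for this difference between ethyl and allyl.

Still open, from the compounds shown here alone, is whether ethyl is a narrow optimum on this aromatic carbon, or whether a longer chain such as butyl, or a small amine, would match or pass it in this assay. Among these compounds, it is also open whether a chain longer than propyl on the saturated chain carbon bound to an aromatic carbon would move the number beyond the scatter, since the only comparison at that place so far, between propyl and methyl, stays within it.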